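The source may report more compounds than this note shows. Statements on the series, on what has been measured and on what is new or still open speak of the compounds shown alone.

Three compounds have been tested in a functional assay on Maver1 cells (Homo sapiens) for inhibition, read by luminescence and CellTiter-Glo, with a stated time of 72 h; on this read-out higher numbers stand for weaker inhibition and lower numbers for stronger inhibition:

compound 1 `C=CC(=O)Nc1cccc(Cn2nc(-c3ccc(Oc4ccccc4)cc3)cc2C(=O)OCC)c1`: 8600 nM
compound 2 `C=CC(=O)Nc1ccc(Cn2nc(-c3ccc(Oc4ccccc4)cc3)cc2C(=O)O)cc1`: > 60000 nM, a limit of the assay and not a number
compound 3 `C/C=C/C(=O)Nc1ccc(Cn2nc(-c3ccc(Oc4ccccc4)cc3)cc2C(=O)OCC)cc1`: > 60000 nM, likewise a limit and not a number

On the numbers shown, compound 2 gives only a limit, (the limit of > 60000 nM in this assay, at which 2 of the 3 values shown sit), so its inhibition is weaker than the assay can resolve. Compound 4 `O=C(CCl)Nc1ccc(Cn2nc(-c3ccc(Oc4ccccc4)cc3)cc2C(=O)O)cc1` is compound 2 with a single change: chloromethyl in place of vinyl on a carbonyl carbon. Among the compounds with values here, no measured step matches this change exactly. Within the data shown here, the one measured step, an at least 6.9-fold higher number from compound 1 to compound 3 (0.84 log units; beyond the scatter), also alters the group on the carbonyl carbon as part of a larger change, and it ended at a limit as well. Compound 2 already sits at the limit (the limit of > 60000 nM in this assay, at which 2 of the 3 values shown sit), so a higher number cannot show, and a result within the scatter of that limit is expected. Compound 4 is therefore estimated at 60000 nM, from 20000 nM to 200000 nM, most likely reported again as a limit. The step expected is a number no higher from compound 2 to compound 4 (the limit leaves the size open).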

Compound 4, half-maximal inhibitory concentration: 1200 nM
Compound 4: middle estimate off by 50-fold (1.70 log units), on the high side, outside the stated range (below it).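

In this assay, the step of an at least 50-fold lower number from compound 2 to compound 4 (1.69 log units; beyond the scatter) shows that the group on the carbonyl carbon can decide whether a compound of this series gives a measurable value at all. The two compounds differ only in chloromethyl against vinyl, so the free carboxylic acid they share does not by itself hold a compound at the limit. Compound 2 gives > 60000 nM, a limit of the assay and not a number, so the step states only a minimum size.

The compounds shown leave open whether bromomethyl or a plain methyl on the same carbonyl carbon would read like chloromethyl, and so whether the chlorine itself matters. As far as these compounds go, how an ethyl ester in place of the carboxylic acid of compound 4 would read also stays open.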